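The source may report more compounds than this note shows. Statements on the series, on what has been measured and on what is new or still open speak of the compounds shown alone.

Compounds measured:
- compound 1, `Nc1ccc(C(=O)Nc2nc(-c3ccccc3)nc3c2nnn3Cc2ccccc2)cc1` — 7.1 nM
- compound 2, `O=C(Nc1nc(-c2ccccc2)nc2c1nnn2Cc1ccccc1)C1CCCC1` — 2.5 nM

Both were tested in an assay (strain Wistar) for displacement of a labelled ligand from adenosine receptor A1 (Rattus norvegicus), read by scintillation counting; a lower number here means a stronger inhibitor, a higher number a weaker inhibitor. For the measured compounds named here, compound 2 stands at the lower of the two numbers; its only neighbour is compound 1, and the step of a 2.8-fold lower number from compound 1 to compound 2 (0.45 log units; beyond the scatter) separates them, so compound 2 is the stronger inhibitor of the pair on this assay.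

The step to compound 3, `O=C(Nc1nc(-c2ccccc2)nc2c1nnn2Cc1ccccc1)c1ccc(Cl)cc1`, is 4-chlorophenyl in place of cyclopentyl on a carbonyl carbon. Going by the values given here, the one measured step that bears on it is a 2.8-fold lower number from compound 1 to compound 2 (0.45 log units; beyond the scatter), in which an aromatic ring on the carbonyl carbon gave way to cyclopentyl and the number fell modestly. Compound 3 goes back to an aromatic ring at that position, so the expectation is a return towards the number of compound 1, with the change from amino to chlorine on that ring not covered by any measured pair and left open.

For compound 3 the estimate is a 2.2-fold higher number from compound 2 to compound 3 (0.34 log units; beyond the scatter), in the direction of a weaker inhibitor, of modest size. The number expected for compound 3 in this assay is 5.5 nM, with a range from 1.8 nM to 17 nM.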

Compound 3, inhibition constant: 108 nM
Beside the measured number, compound 3's estimate is 20-fold (1.29 log units) below it, and the stated range ends below it.
By their numbers in this assay, from the lowest: compound 2; then compound 1; then compound 3.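

In this assay, an aromatic ring on the carbonyl carbon does not by itself set the number: with chloro in place of amino on an aromatic carbon, the record shows a 15-fold higher number from compound 1 to compound 3 (1.18 log units; beyond the scatter), so the group carried on that ring matters at least as much as the ring itself. The exchange of cyclopentyl for 4-chlorophenyl on the same carbonyl carbon gives a 43-fold higher number from compound 2 to compound 3 (1.64 log units; beyond the scatter), far larger than the modest 2.8-fold lower number from compound 1 to compound 2 (0.45 log units; beyond the scatter), so this position tolerates some aromatic groups and not others, and compound 1 and compound 3 now mark that contrast within one pair. No measurement among the data shown accounts for the size of these steps.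

As far as these compounds go, whether chloro raises the number or amino lowers it remains open, and an unsubstituted phenyl on the carbonyl carbon, together with 4-methoxyphenyl or 4-hydroxyphenyl, would help to separate the two readings. From the compounds shown here alone, how far the low number of compound 2 extends among non-aromatic groups also remains open, and cyclohexyl, cyclobutyl or a straight butyl chain on the same carbonyl carbon would test it.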